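The compounds below may be only part of what the source reports. "The series", "measured", "known", "first", "only" and "open" are said of these compounds alone.

Working notes on the series. Three compounds are measured: compound 1 `COc1cc2c(Oc3ccc(NC(=O)c4cn(-c5ccccc5C)nn4)cc3F)ccnc2cc1OCCCN1CCCC1`, compound 2 `COc1cc2c(Oc3ccc(NC(=O)c4cn(-c5ccc(Br)cc5)nn4)cc3F)ccnc2cc1OCCCN1CCCC1` and compound 3 `COc1cc2c(Oc3ccc(NC(=O)c4cn(-c5ccccc5C)nn4)cc3F)ccnc2cc1OCCCN1CCCCC1`, all in a functional assay on A549 cells (Homo sapiens) for cytotoxicity, read by MTT assay, with a stated time of 72 h; a higher number here means a weaker inhibitor, a lower number a stronger inhibitor. Compound 1 gives 900 nM, compound 2 gives 370 nM, and compound 3 gives 3230 nM, the highest of the three numbers. The two single-point steps are a 2.4-fold lower number from compound 1 to compound 2 (0.39 log units; beyond the scatter) and a 3.6-fold higher number from compound 1 to compound 3 (0.55 log units; beyond the scatter). Compound 4 `COc1cc2c(Oc3ccc(NC(=O)c4cn(-c5c(Cl)cccc5Cl)nn4)cc3F)ccnc2cc1OCCCN1CCCCC1` is not yet measured; it differs from compound 3 by 2,6-dichlorophenyl in place of 2-methylphenyl on an aromatic nitrogen. Of the measured steps only a 2.4-fold lower number from compound 1 to compound 2 (0.39 log units; beyond the scatter) bears on this change, there too 2-methylphenyl gave way to a halogen-bearing phenyl, and that step was modest. For compound 4 a modest lowering is therefore expected, about a 1.6-fold lower number from compound 3 to compound 4 (0.21 log units; within the scatter), with wide uncertainty. Compound 4 is estimated at 2000 nM, range 600 nM to 6000 nM.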

Compound 4, half-maximal inhibitory concentration: 150 nM
Estimate against measurement, compound 4: 13-fold (1.12 log units) above; the measured number lies below the stated range.
By their numbers in this assay, from the lowest: compound 4; then compound 2; then compound 1; then compound 3.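

On the aromatic nitrogen of the five-membered ring, 2,6-dichlorophenyl in place of 2-methylphenyl gives a 22-fold lower number from compound 3 to compound 4 (1.33 log units; beyond the scatter) in this assay on the piperidin-1-yl chain. This position can therefore move the number far more than the modest 2.4-fold lower number from compound 1 to compound 2 (0.39 log units; beyond the scatter) showed for 4-bromophenyl on the pyrrolidin-1-yl chain. Nothing available accounts for the size of this step.

Open, from the compounds shown here alone, is whether 2,6-dichlorophenyl on the pyrrolidin-1-yl chain of compound 1 gives a step of similar size. Also open, going by these compounds, is whether 2-chlorophenyl or 2,6-dimethylphenyl would hold the lower number.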